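The compounds below may be only part of what the source reports. "The series", "measured", "known", "first", "only" and "open" are said of these compounds alone.

Measured compounds:
compound 1 `O=C(Nc1ccc(S(=O)(=O)N2CCCCC2)c2ccccc12)c1ccccc1` — > 30000 nM
compound 2 `CCOC(=O)N1CCC(NS(=O)(=O)c2ccc(C(=O)Nc3ccccc3C)c3ccccc23)CC1` — 5.21 nM

In an assay on L1.2 cells for binding affinity to C-C chemokine receptor type 8 (Homo sapiens) (on this read-out higher numbers stand for weaker inhibition and lower numbers for stronger inhibition), compound 1 gives only a limit of the assay, > 30000 nM. In this assay, going by the values given here, compound 2 gives 5.21 nM, the only actual number among the two measured compounds. Compound 3 `CCOC(=O)N1CCC(NS(=O)(=O)c2ccc(OC(=O)c3ccccc3)c3ccccc23)CC1` is not yet measured. It differs from compound 2 in one place: benzoyloxy in place of (2-methylphenyl)carbamoyl on an aromatic carbon. Swapping the amide that links the two aromatic parts for an ester removes the amide hydrogen, and a step weakening binding is expected, larger than the usual scatter. The step expected from compound 2 to compound 3 in this assay is a 29-fold higher number from compound 2 to compound 3 (1.46 log units; beyond the scatter). For compound 3 the estimated value in this assay is 150 nM, with a range from 20 nM to 3000 nM.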

Compound 3, inhibition constant: 16.4 nM
Estimate against measurement, compound 3: 9.1-fold (0.96 log units) above, and the stated range ends above it.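

In this assay, benzoyloxy in place of (2-methylphenyl)carbamoyl, on the aromatic carbon para to a large group, gives a 3.1-fold higher number from compound 2 to compound 3 (0.50 log units; beyond the scatter). This is a modest loss: at this position, a group with no hydrogen-bond donor still allows measurable binding, and the amide hydrogen is not essential for it. No measurement shown accounts for the size of this step.

The swap also removes the methyl on the outer ring, leaving the contributions of the link and the methyl unseparated. On these data alone, how an amine or a carboxylic acid at this position would behave remains open.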